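The source may hold more compounds than are shown below. What is called first, only, known or untested is meant among the compounds shown, and "the series" means these compounds.

Compounds measured in an assay on HEK293 cells for displacement of a labelled ligand from adenosine receptor A2b (Homo sapiens); a lower number here means a stronger inhibitor, a higher number a weaker inhibitor:

compound 1, `CCn1c(=O)c2[nH]c(-c3ccc(S(=O)(=O)NC4CCN(Cc5ccc(F)cc5)CC4)cc3)cc2n(CC)c1=O` — 12 nM
compound 2, `Cn1c(=O)c2[nH]c(-c3ccc(S(=O)(=O)N4CCN(Cc5ccc(F)cc5)CC4)cc3)cc2n(C)c1=O` — 10 nM
compound 3, `Cn1c(=O)c2[nH]c(-c3ccc(S(=O)(=O)NC4CCN(Cc5ccccc5)CC4)cc3)cc2n(C)c1=O` — 43 nM

Compound 2 has the smallest number of the three, but compound 1 lies within the scatter of it, so the two cannot be told apart; only compound 3, whose number is beyond the scatter of compound 2, stands clearly apart. No two of these compounds differ in one place only, so no single step can be read from them directly.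

Compound 4, `Cn1c(=O)c2[nH]c(-c3ccc(S(=O)(=O)N4CCN(c5ccccc5)CC4)cc3)cc2n(C)c1=O`, has not yet been measured. It differs from compound 2 in one place: phenyl in place of 4-fluorobenzyl on an amine nitrogen in a ring. The group that leaves is larger than the one that enters, and the entering phenyl sits directly on the ring nitrogen.

For the measured compounds named here, no measured pair shows this change, so what is expected rests only on the three numbers above. Compound 3, with 43 nM, shows that a change at the far end of this side chain can move the number beyond the scatter, though that pair also differs elsewhere. For compound 4 the number in this assay is expected to be higher than that of compound 2, the step from compound 2 to compound 4 being estimated at a 4.0-fold higher number from compound 2 to compound 4 (0.60 log units; beyond the scatter). Compound 4 is therefore expected to give about 40 nM, with a range from 10 nM to 160 nM.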

Compound 4, half-maximal inhibitory concentration: 6 nM
Beside the measured number, compound 4's estimate is 6.7-fold (0.82 log units) above it, outside the stated range (below it).
By their numbers in this assay, from the lowest: compounds 4, 2 and 1 (each within the scatter of the next); then compound 3.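

In this assay, phenyl in place of 4-fluorobenzyl on the amine nitrogen in the ring gives a 1.7-fold lower number from compound 2 to compound 4 (0.22 log units; within the scatter), so compound 2 and compound 4 cannot be told apart. For the compounds shown here, this is the first direct reading at this position, and it shows that the number stays within the scatter when the group goes from 8 heavy atoms to 6, loses its fluorine and has its aromatic ring directly on the ring nitrogen. Nothing given here explains why the number holds across this change.

Because this one step alters the fluorine and the link to the ring nitrogen together, the compounds shown do not separate the two, and an unsubstituted benzyl or a 4-fluorophenyl group on the same nitrogen would be needed to read each alone. They also leave open how far this position stays within the scatter with other groups, such as a longer chain like 2-phenylethyl, a pyridine ring in place of the phenyl, or a carboxylic acid on the phenyl ring.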